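Bromo in place of benzoyl: what to expect

This account rests on a few compounds, and the source may have more. Where it says the series, first, only, none or still open, it means among the compounds named here.

Compound 1 `C=CCc1ccc(OCc2cn(-c3ccccc3Cl)nn2)c(O)c1` gives 46.6%
Compound 2 `C=CCc1ccc(OCc2cn(-c3cccc(C#N)c3)nn2)c(O)c1` gives 26.6%
Compound 3 `C=CCc1ccc(OCc2cn(-c3ccc(C(=O)c4ccccc4)cc3)nn2)c(O)c1` gives 40.1%

These three compounds share one core and differ only in the group on an aromatic nitrogen. In a functional assay on MIA PaCa-2 cells (Homo sapiens) for inhibition, read by MTT assay, with a stated time of 72 h, tested at 30 uM (a lower number here means less inhibition of growth, a higher number more inhibition of growth at the concentration tested), compound 3 at 40.1% lies within the usual scatter of compound 1 and beyond the scatter above compound 2.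

The question now is compound 4 `C=CCc1ccc(OCc2cn(-c3ccc(Br)cc3)nn2)c(O)c1` which keeps the core and makes one change: bromo in place of benzoyl on an aromatic carbon. Here bromo takes the place of benzoyl on an aromatic carbon, para to a large group.

Among the measured compounds shown here, only one measured step touches this part of the molecule: a number 20 percentage points lower from compound 1 to compound 2 (beyond the scatter). It shows that a change here can move the reading beyond the scatter. But it involves neither bromo nor benzoyl, so it offers a size and no direction. The closest comparison is compound 1 at 46.6% whose group holds chlorine rather than bromine.

On this thin evidence, no step beyond the scatter is expected, although a step as large as the measured one cannot be excluded. The estimated change is a number 1.9 percentage points higher from compound 3 to compound 4 (within the scatter) and remains small. Compound 4 is estimated at 42% with an expected range from 28% to 56% as its likely span.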

Compound 4, percent growth inhibition at one concentration: 43.3%
Beside the measured number, compound 4's estimate is 1.3 percentage points below it; the measured number falls inside the stated range.
By their numbers in this assay, from the lowest: compound 2; then compounds 3, 4 and 1 (each within the scatter of the next).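

In this assay, a single bromo takes the place of benzoyl, with its eight heavy atoms and its aromatic ring, and the result is a number 3.2 percentage points higher from compound 3 to compound 4 (within the scatter), so on this aromatic carbon the two groups cannot be told apart despite their very different size. The change of the whole group on the aromatic nitrogen gives a similar picture with 4-bromophenyl in place of 2-chlorophenyl, a number 3.3 percentage points lower from compound 1 to compound 4 (within the scatter), whereas 4-bromophenyl in place of 3-cyanophenyl gives a number 16.7 percentage points higher from compound 2 to compound 4 (beyond the scatter), which sets compound 2 apart from compound 4 by a modest step. Nothing measured here explains why compound 2 differs in this way.

Benzoyl and bromo are only two groups on this carbon, so it remains open whether an amine or a carboxylic acid there would leave the reading in the same range. On these data alone, it is also open whether compounds that read alike in this single-concentration test would still match across a full range of concentrations.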